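The source may hold more compounds than are shown below. What is called first, only, known or untested is meant among the compounds shown, and "the series" means these compounds.

Compound 1 `CC(C)(C)Cc1c(-c2ccc(F)cc2F)sc(N)c1C(=O)c1ccc(Cl)cc1` and compound 2 `Cc1ccc(C(=O)c2c(N)sc(Br)c2CC(C)(C)C)cc1` are the two substances for which a result exists here. In an assay on CHO cells for displacement of a labelled ligand from adenosine receptor A3 (Homo sapiens), read by scintillation counting, tested at 10 uM (a higher number here means more inhibition at the concentration tested (going by the name of the read-out), a lower number less inhibition), compound 1 gives 1%, and compound 2 gives 1%; the two readings stand level within the usual scatter, so neither shows any clear displacement of the labelled ligand at the concentration tested. Compound 1 therefore sits at the bottom of the range, with essentially no measurable inhibition. Compound 3 `Cc1noc(C)c1-c1sc(N)c(C(=O)c2ccc(Cl)cc2)c1CC(C)(C)C` has not yet been measured. It differs from compound 1 in one place: 3,5-dimethyl-1,2-oxazol-4-yl in place of 2,4-difluorophenyl on an aromatic carbon. Among the compounds with values here, nothing measured so far indicates how this kind of swap affects the reading; the two known readings stand level with each other. The step is expected to be small, a number 2 percentage points higher from compound 1 to compound 3 (within the scatter), not beyond the scatter in either direction. Compound 3 is expected to give 3%, with a plausible range from -8% to 15%.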

Compound 3, a percentage reported as inhibition, at one concentration (the size of the read-out at that concentration, not a potency): 1%
The estimate for compound 3 lay 2 percentage points above the measured number; the measured number falls inside the stated range.
By their numbers in this assay, from the lowest: compounds 1, 2 and 3 (each within the scatter of the next).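

At this aromatic carbon next to the ring sulfur, putting 3,5-dimethyl-1,2-oxazol-4-yl in place of 2,4-difluorophenyl gives no change at the digits printed from compound 1 to compound 3 (within the scatter) in this assay. A six-membered aromatic ring of carbon only and a five-membered aromatic ring with 2 hetero atoms and 2 hydrogen-bond acceptors thus both leave the reading at the bottom of the range, so this exchange brings no clear displacement of the labelled ligand at the concentration tested. Nothing available explains this flat result.

With readings this close to nothing, a harmful change at this position could hardly be seen, so only a clear rise would be informative. Going by these compounds, whether a basic amine such as piperidine, a carboxylic acid or a longer alkyl chain on this carbon would produce such a rise stays open.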